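This account rests on a few compounds, and the source may have more. Where it says the series, first, only, none or still open, it means among the compounds named here.

Measured compounds so far:
compound 1 `CC(=O)OC[C@H]1O[C@@H](CC(=O)/C=C/c2cc(Cl)cc(Cl)c2O)[C@H](OC(C)=O)[C@@H](OC(C)=O)[C@@H]1OC(C)=O` — in an ADME assay on cells (Epithelial cell, Homo sapiens) for cytotoxicity, read by MTT assay, with a stated time of 24 h (on this read-out higher numbers stand for lower toxicity in this test and lower numbers for higher toxicity in this test), compound 1 gives "not determined" (no result reported)
compound 2 `COc1cc(/C=C/C(=O)C[C@@H]2O[C@H](COC(C)=O)[C@@H](OC(C)=O)[C@H](OC(C)=O)[C@H]2OC(C)=O)ccc1O` — in this assay compound 2 gives "not determined" (no result reported)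
compound 3 `CC(=O)OC[C@H]1O[C@@H](CC(=O)/C=C/c2ccc(Cl)c(Cl)c2)[C@H](OC(C)=O)[C@@H](OC(C)=O)[C@@H]1OC(C)=O` — in this assay compound 3 gives 25.8 nM

Going by the values given here, compound 3 therefore stands as the only compound with a number in this assay; compound 1 and compound 2 carry no number at all, so nothing can be said about how they compare. Compound 4 `CC(=O)OC[C@H]1O[C@@H](CC(=O)/C=C/c2ccc(C(F)(F)F)cc2)[C@H](OC(C)=O)[C@@H](OC(C)=O)[C@@H]1OC(C)=O` is not yet measured. It differs from compound 3 in one place: 4-(trifluoromethyl)phenyl in place of 3,4-dichlorophenyl on a double-bonded chain carbon bound to a double-bonded chain carbon. Among the compounds with values here, no pair of measured compounds shows how a change of this kind moves the read-out, so there is no step to lean on. The expected step from compound 3 to compound 4 is a 1.6-fold higher number from compound 3 to compound 4 (0.19 log units; within the scatter), a small shift that is not expected to go beyond the usual scatter. For compound 4 the estimated value in this assay is 40 nM, with a range from 10 nM to 160 nM.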

Compound 4, half-maximal cytotoxic concentration: 103 nM
For compound 4 the middle estimate is 2.6-fold (0.41 log units) below the measured one, within the range that was stated.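

In this assay, putting 4-(trifluoromethyl)phenyl in place of 3,4-dichlorophenyl gives a 4.0-fold higher number from compound 3 to compound 4 (0.60 log units; beyond the scatter), so the read-out responds to which group sits at this place on the chain, and here the change means lower toxicity in this test. No measurement shown explains this shift. On these data alone, the swap removes both chlorines and adds the trifluoromethyl group in one move, so their separate contributions remain open. As far as these compounds go, how an amine or a carboxylic acid on the phenyl ring would behave also remains open.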